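Methyl on the benzyl group: cytotoxicity notes for the series

The source may hold more compounds than are shown below. What is called first, only, known or untested is meant among the compounds shown, and "the series" means these compounds.

The three measured compounds share one core carrying a dinitro-substituted aromatic ring. In an ADME assay on CHO-K1 cells (Cricetulus griseus) for cytotoxicity, read by MTT assay, with a stated time of 24 h (on this read-out lower numbers stand for stronger inhibition and higher numbers for weaker inhibition), compound 3 `O=[N+]([O-])c1cc(-c2nnn(Cc3ccccc3)n2)cc([N+](=O)[O-])c1` gives 150000 nM, the highest of the two numbers available, while compound 1 `O=[N+]([O-])c1cc(Sc2nnnn2Cc2ccccc2)cc([N+](=O)[O-])c1` gives 127000 nM, which lies within the scatter of compound 3. Compound 2 `CCCCCCCCCCCCn1nnc(-c2cc([N+](=O)[O-])cc([N+](=O)[O-])c2)n1` returns only a limit, > 200000 nM, and so supplies no number for comparison. Compound 4 `Cc1ccc(Cn2nnc(-c3cc([N+](=O)[O-])cc([N+](=O)[O-])c3)n2)cc1` differs from compound 3 by methyl in place of hydrogen on an aromatic carbon. Among the compounds with values here, no measured pair isolates this change. The expected step in this assay is a 1.1-fold lower number from compound 3 to compound 4 (0.03 log units; within the scatter), which is no change beyond the scatter. Compound 4 is estimated at 140000 nM, with a range from 70000 nM to 280000 nM.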

Compound 4, half-maximal inhibitory concentration: 200000 nM
Compound 4: middle estimate off by 1.4-fold (0.15 log units), on the low side; the range from low to high includes it.
By their numbers in this assay, from the lowest: compounds 1, 3 and 4 (each within the scatter of the next).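

In this assay, within the data shown here, the change from benzyl to 4-methylbenzyl gives the first measured step at this position, and it is a 1.3-fold higher number from compound 3 to compound 4 (0.12 log units; within the scatter) and so shows that methyl in place of hydrogen here, para to a large group, leaves the number within the usual scatter. Compound 2 gives a limit, not a number, and the values of this series lie close to it: the limit of > 200000 nM in this assay, at which 1 of the 4 values shown sits.

Still open, from the compounds shown here alone, is whether an amine, a carboxylic acid or a longer chain in place of this methyl would move the number beyond the scatter.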